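Aryl replacement on the shared core: outlook for compound 4

The compounds below may be only part of what the source reports. "The series", "measured", "known", "first", "only" and "open" are said of these compounds alone.

Compound 3 `Cc1nc(C)n(CC(=O)N2CCN(c3sc(C(F)(F)F)nc3-c3cnc(C4CC4)nc3)C[C@H]2C)n1` in an assay on blood for inhibition of C-X-C chemokine receptor type 3 (Homo sapiens), with a stated time of 30 min (a higher number here means a weaker inhibitor, a lower number a stronger inhibitor), gives 674 nM, the second highest of the three numbers, yet within the scatter of both neighbours: compound 2 `Cc1ncc(-c2nc(C(F)(F)F)sc2N2CCN(C(=O)Cn3nc(C)nc3C)[C@H](C)C2)cn1` gives 610 nM and compound 1 `COc1ncc(-c2nc(C(F)(F)F)sc2N2CCN(C(=O)Cn3nc(C)nc3C)[C@H](C)C2)cn1` gives 1040 nM. Compound 4 `COc1ccc(-c2nc(C(F)(F)F)sc2N2CCN(C(=O)Cn3nc(C)nc3C)[C@H](C)C2)cn1` is not yet measured; it differs from compound 3 by 6-methoxypyridin-3-yl in place of 2-cyclopropylpyrimidin-5-yl on an aromatic carbon. The measured steps concern only the small group on the six-membered aromatic ring: a 1.7-fold lower number from compound 1 to compound 2 (0.23 log units; within the scatter), a 1.5-fold lower number from compound 1 to compound 3 (0.19 log units; within the scatter) and a 1.1-fold higher number from compound 2 to compound 3 (0.04 log units; within the scatter), each within the scatter. Going by the values given here, no step covers the exchange of the whole 2-cyclopropylpyrimidin-5-yl for 6-methoxypyridin-3-yl, so the ring change itself is untested. The methoxy group is already seen on compound 1 with 1040 nM, and the three substituents so far give a flat response. Accordingly no step beyond the scatter is expected in this assay. The expected step is a 1.3-fold higher number from compound 3 to compound 4 (0.10 log units; within the scatter). Compound 4 is expected to give 850 nM, with a range of 350 nM to 2100 nM.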

Compound 4, half-maximal inhibitory concentration: 1580 nM
For compound 4 the middle estimate is 1.9-fold (0.27 log units) below the measured one; the measured number falls inside the stated range.
By their numbers in this assay, from the lowest: compounds 2, 3, 1 and 4 (each within the scatter of the next, the first and the last beyond it).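

In this assay, going by these compounds alone, exchanging the whole six-membered aromatic ring and its small group gives the first steps beyond the scatter at this position: a 2.3-fold higher number from compound 3 to compound 4 (0.37 log units; beyond the scatter) and a 2.6-fold higher number from compound 2 to compound 4 (0.41 log units; beyond the scatter). With methoxy kept on both sides, 6-methoxypyridin-3-yl in place of 2-methoxypyrimidin-5-yl gives only a 1.5-fold higher number from compound 1 to compound 4 (0.18 log units; within the scatter), so the ring exchange alone is not resolved from the scatter. The two larger steps change both ring and small group at once, and no measured evidence on the origin of either step is at hand.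

Still open, from the compounds shown here alone, is whether methyl or cyclopropyl on the pyridine ring, as in 6-methylpyridin-3-yl or 6-cyclopropylpyridin-3-yl, would match their pyrimidine counterparts. Also open, going by these compounds, is how an amine or a carboxylic acid as the small group would read in this assay.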